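The source may hold more compounds than are shown below. What is called first, only, known or untested is meant among the compounds shown, and "the series" means these compounds.

This account concerns four compounds from one study, each judged by how strongly it slows the growth of a kidney cancer cell line in a functional assay on RCC4 cells (Homo sapiens) for antiproliferative activity, read by XTT assay, with a stated time of 48 h; on this read-out higher numbers stand for weaker inhibition and lower numbers for stronger inhibition. Compound 1 `COc1cccc(N(Cc2cn([C@@H]3O[C@H](COC(C)=O)[C@@H](OC(C)=O)[C@H]3OC(C)=O)nn2)S(C)(=O)=O)c1` gives 190000 nM in this assay. Compound 2 `CC(=O)OC[C@H]1O[C@@H](n2cc(CN(c3ccc(C#N)cc3)S(C)(=O)=O)nn2)[C@H](OC(C)=O)[C@@H]1OC(C)=O` carries a single alteration relative to compound 1, namely (4-cyanophenyl in place of 3-methoxyphenyl on a sulfonamide nitrogen), and in this assay compound 2 gives 235000 nM. The step itself is a 1.2-fold higher number from compound 1 to compound 2 (0.09 log units; within the scatter), so this change left the activity essentially unchanged within that pair.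

Compound 3 `COc1cccc(N(Cc2cn([C@@H]3O[C@H](COC(C)=O)[C@@H](OC(C)=O)[C@H](OC(C)=O)[C@H]3OC(C)=O)nn2)S(C)(=O)=O)c1` is built on a different core, and the difference between the core of compound 1 and the core of compound 3 is not broken down here. In this assay compound 3 gives 200000 nM, a value that lies within the usual scatter of those of compound 1 and compound 2, so no ranking among the three can be drawn.

Compound 4 `CC(=O)OC[C@H]1O[C@@H](n2cc(CN(c3ccc(C#N)cc3)S(C)(=O)=O)nn2)[C@H](OC(C)=O)[C@@H](OC(C)=O)[C@@H]1OC(C)=O` has not yet been measured. Among the measured compounds shown here, it differs from compound 3 by 4-cyanophenyl in place of 3-methoxyphenyl on a sulfonamide nitrogen, the same change as the one from compound 1 to compound 2, made at the same place. Because the earlier step was a 1.2-fold higher number from compound 1 to compound 2 (0.09 log units; within the scatter), the step from compound 3 to compound 4 is expected to be a 1.2-fold higher number from compound 3 to compound 4 (0.08 log units; within the scatter), again within the scatter. Compound 4 is therefore estimated at 240000 nM in this assay. Its likely range is expected to run from 120000 nM to 480000 nM.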

Compound 4, half-maximal inhibitory concentration: 120000 nM
Beside the measured number, compound 4's estimate is 2.0-fold (0.30 log units) above it; the range from low to high includes it.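

In this assay, putting 4-cyanophenyl in place of 3-methoxyphenyl on the sulfonamide nitrogen gives a 1.7-fold lower number from compound 3 to compound 4 (0.22 log units; within the scatter) and so, as on the core of compound 1, this change on the core of compound 3 stays within the ordinary variation between repeat measurements. Set side by side, the two steps point in opposite directions, yet the gap between them is no larger than such variation allows: the same change on two cores in this assay, a 1.2-fold higher number (0.09 log units; within the scatter) from compound 1 to compound 2 and a 1.7-fold lower number (0.22 log units; within the scatter) from compound 3 to compound 4, 2.1-fold (0.31 log units) apart, within the scatter of two such steps. This shows that the change behaves alike on these two cores, in that neither step can be told apart from no change at all, so the opposite directions should not be read as a reversal; it does not show that the change has a real effect of any size, nor that the same would hold on a third core.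

The compounds shown leave open whether a different group on the sulfonamide nitrogen, such as a phenyl ring bearing a carboxylic acid or an amine, would shift the number beyond the scatter. They also leave open what would happen if the acetyl groups on the core gave way to free hydroxyl groups, or the methyl on the sulfonyl sulfur to a longer chain.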